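The source may hold more compounds than are shown below. What is called first, only, known or untested is meant among the compounds shown, and "the series" means these compounds.

Of the compounds shown here, two have numbers so far. In a functional assay on HeLa cells (Homo sapiens) for inhibition, read by MTT assay, with a stated time of 72 h (a higher number here means a weaker inhibitor, a lower number a stronger inhibitor), compound 1 (`c1ccc(-c2nnc(SCCCN3CCN(c4nc5ccccc5o4)CC3)o2)cc1`) gives 67000 nM and compound 2 (`CC(C)(C)Oc1ccc(-c2nnc(SCCCN3CCN(c4nc5ccccc5s4)CC3)o2)cc1`) gives 217000 nM as the higher of the two numbers, a gap that lies beyond the scatter. Compound 3 (`c1ccc(-c2nnc(SCCCN3CCN(c4nc5ccccc5s4)CC3)o2)cc1`) remains unmeasured and departs from compound 2 in one place. The change is hydrogen in place of tert-butoxy on an aromatic carbon, which turns 4-(tert-butoxy)phenyl into phenyl. For the measured compounds named here, no measured pair isolates this change, so any forecast rests on two values only. Going by the values given here, compound 1 at 67000 nM is the only lower number available and serves as the guide for the expectation. A move towards a lower number in this assay is expected, smaller than the gap between the two measured compounds, and a result within the scatter of compound 2 remains possible. The estimated move is a 2.2-fold lower number from compound 2 to compound 3 (0.34 log units; beyond the scatter) in that direction. For compound 3 the expected value is 100000 nM with an estimated range from 35000 nM to 250000 nM in this series.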

Compound 3, half-maximal inhibitory concentration: 229000 nM
For compound 3 the middle estimate is 2.3-fold (0.36 log units) below the measured one; the measured number falls inside the stated range.
By their numbers in this assay, from the lowest: compound 1; then compounds 2 and 3 (each within the scatter of the next).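

In this assay, hydrogen in place of tert-butoxy on the aromatic carbon gives a 1.1-fold higher number from compound 2 to compound 3 (0.02 log units; within the scatter) and so, with 1,3-benzothiazol-2-yl on the ring nitrogen, this position shows no readable response to the loss of that group. The same compound links the series at the other end: 1,3-benzothiazol-2-yl in place of 1,3-benzoxazol-2-yl on the amine nitrogen in the ring gives a 3.4-fold higher number from compound 1 to compound 3 (0.53 log units; beyond the scatter) and, though modest, this is the only one of the two steps beyond the scatter, so among these three compounds the readable difference sits with that ring substituent and not with the tert-butoxy group. No measurement here bears on the reason for either step.

Going by these compounds, whether the flat result at this aromatic carbon holds for other groups there, such as an amine, a carboxylic acid or a methoxy group, stays open. For the compounds shown here, also open is whether tert-butoxy would give the same flat result with 1,3-benzoxazol-2-yl on the ring nitrogen, since the one readable pair for this change carries 1,3-benzothiazol-2-yl.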